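The source may report more compounds than this note shows. Statements on the series, on what has been measured and on what is new or still open speak of the compounds shown alone.

Measured compounds:
- compound 1, `COc1cc(CNC(=O)/C=C/c2ccccc2OCc2nc(C)c(C)nc2C)ccc1O`: 12000 nM
- compound 2, `COc1cc(CNC(=O)/C=C/c2ccccc2O)ccc1OCc1nc(C)c(C)nc1C`: 5300 nM

In a functional assay on SH-SY5Y cells (Homo sapiens) for cytotoxicity, read by MTT assay, with stated times of 24 h and 4 h (a lower number here means that less compound is needed, a higher number that more compound is needed for the effect), compound 1 gives 12000 nM, and compound 2 gives 5300 nM. Compound 2 therefore has the lowest of the two numbers in this assay, and compound 1 stands a clear step higher, beyond the usual scatter. The two compounds share the same core and differ only in which of the two aromatic oxygens carries the (3,5,6-trimethylpyrazin-2-yl)methyl group; no direct one-step comparison between them is drawn here, only their two values.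

Compound 3, `COc1cc(CNC(=O)/C=C/c2ccccc2OCc2nc(C)c(C)nc2C)ccc1OCc1nc(C)c(C)nc1C`, carries that group on both oxygens. Going from compound 2 to compound 3, the change is (3,5,6-trimethylpyrazin-2-yl)methyl in place of hydrogen on an oxygen on an aromatic ring. Because compound 1, which carries this group on that same oxygen while the other oxygen is free, shows 12000 nM, the expectation is that capping the second oxygen will push the number somewhat upward rather than downward, by a step of about a 1.5-fold higher number from compound 2 to compound 3 (0.18 log units; within the scatter) in this assay. Compound 3 is thus estimated at 8000 nM, with a plausible range from 3000 nM to 22000 nM.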

Compound 3, half-maximal effective concentration: 6280 nM
Compound 3: the middle estimate sits 1.3-fold (0.11 log units) above what was measured; the range from low to high includes it.
By their numbers in this assay, from the lowest: compounds 2, 3 and 1 (each within the scatter of the next, the first and the last beyond it).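

Going by these compounds alone, compound 3 allows the first direct readings of one change, (3,5,6-trimethylpyrazin-2-yl)methyl in place of hydrogen on an oxygen on an aromatic ring, made at each of the two oxygens of the shared core. In this assay this change gives a 1.2-fold higher number from compound 2 to compound 3 (0.07 log units; within the scatter) at one oxygen and a 1.9-fold lower number from compound 1 to compound 3 (0.28 log units; within the scatter) at the other. With one oxygen already carrying the group, adding it to the second therefore produces no readable shift in this assay, whichever oxygen is capped, although each step rests on a single pair of compounds. No measurement shown here explains these numbers.

The compounds leave open how the core with hydrogen on both oxygens would stand, since every compound here carries the (3,5,6-trimethylpyrazin-2-yl)methyl group on at least one oxygen. They also leave open whether a plain methyl group, a longer carbon chain or a chain ending in an amine or a carboxylic acid on either oxygen would read the same way, or whether this flat result belongs to the trimethylpyrazine group alone.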